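The compounds below may be only part of what the source reports. "The series", "measured", "known", "first", "only" and "open" are said of these compounds alone.

Measured in a functional assay on KG-1 cells (Homo sapiens) for cytotoxicity, read by luminescence and CellTiter-Glo, with a stated time of 3 days; on this read-out lower numbers stand for stronger inhibition and higher numbers for weaker inhibition:
- compound 1 `O=C(Nc1ccc(C(F)(F)F)cc1)c1cc(Cl)c(-c2ccccc2)cc1O`: 770 nM
- compound 2 `O=C(Nc1ccc(C(F)(F)F)cc1)c1cc(Br)ccc1O`: 610 nM

These two values lie within the usual scatter of each other, so compound 2 cannot be ranked apart from compound 1, at 770 nM. The next compound to be tested is compound 3 `O=C(Nc1ccc(C(F)(F)F)cc1)c1cc(Br)c(-c2ccccc2)cc1O`, which differs from compound 2 in one place: phenyl in place of hydrogen on an aromatic carbon. In words, this is phenyl in place of hydrogen on an aromatic carbon.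

Within the data shown here, no measured pair isolates this change, so the data give no direct size for it. Compound 1 also carries a phenyl group and gives 770 nM, which points to no expected shift beyond the scatter in this assay, in either direction. The expected size is a 1.1-fold higher number from compound 2 to compound 3 (0.06 log units; within the scatter). Compound 3 is estimated at 700 nM, with an expected range of 300 nM to 1600 nM.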

Compound 3, half-maximal inhibitory concentration: 400 nM
Compound 3: middle estimate off by 1.8-fold (0.24 log units), on the high side, and the stated range covers the measured number.
By their numbers in this assay, from the lowest: compounds 3, 2 and 1 (each within the scatter of the next).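

In this assay, placing phenyl on the aromatic carbon ortho to the bromo group gives a 1.5-fold lower number from compound 2 to compound 3 (0.18 log units; within the scatter), so this position accepts a whole extra ring with no shift that can be separated from the scatter. With the phenyl in place, bromo in place of chloro gives a 1.9-fold lower number from compound 1 to compound 3 (0.28 log units; within the scatter), so these two halogens cannot be told apart here either. No measured property bears on these results, and the data offer no explanation for them.

Phenyl is the only group other than hydrogen shown at this position, so it remains open how an amine, a carboxylic acid or a longer alkyl chain would behave there. The hydroxy and trifluoromethyl groups stay the same throughout, which leaves their contribution to the activity unknown.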